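The source may report more compounds than this note shows. Statements on the series, on what has been measured and on what is new or still open speak of the compounds shown alone.

Of the compounds shown here, three built on one shared core have been tested in an ADME assay on Huh-7 cells (Homo sapiens) for cytotoxicity; on this read-out lower numbers stand for higher toxicity in this test and higher numbers for lower toxicity in this test. Compound 1 `Cc1ccccc1-c1nn(-c2cccc(Cl)c2)cc1CNCCN1CCN(C)CC1` gives 16000 nM. Compound 3 `CSc1ccc(-n2cc(CNCCN3CCN(C)CC3)c(-c3ccccc3C)n2)cc1` gives 17000 nM. For compound 2 `Cc1ccccc1-c1nn(-c2ccc(N)cc2)cc1CNCCN1CCN(C)CC1` the assay reports only a limit, not a number, namely > 20000 nM (the limit of > 20000 nM in this assay, at which 1 of the 3 values shown sits). Each of these compounds carries a different ring on the aromatic nitrogen of the core, and none of the exchanges moved the read-out beyond the usual scatter: there was a 1.1-fold higher number from compound 1 to compound 3 (0.03 log units; within the scatter), an at least 1.2-fold higher number from compound 1 to compound 2 (0.09 log units; that floor lies within the scatter) and an at least 1.1-fold lower number from compound 2 to compound 3 (0.07 log units; that floor lies within the scatter). Compound 3 therefore stands level with compound 1, the two numbers lying within the scatter of each other, while compound 2 sits at the limit.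

Compound 4 `Cc1ccccc1-c1nn(-c2cc(F)ccc2F)cc1CNCCN1CCN(C)CC1` continues the same kind of exchange: 2,5-difluorophenyl in place of 4-(methylsulfanyl)phenyl on an aromatic nitrogen. Going by the values given here, three measured steps bear on it, all exchanges of the group on that aromatic nitrogen, and all of them were within the scatter. Nothing among these compounds suggests that this fourth ring should behave differently, so no step beyond the scatter is expected in this assay in either direction. The expected step of no change at the digits printed from compound 3 to compound 4 (within the scatter) is estimated to stay within the scatter. Compound 4 is therefore expected to give about 17000 nM, with a likely range from 8000 nM to 35000 nM.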

Compound 4, half-maximal cytotoxic concentration: > 20000 nM
Compound 4: a limit, no number; the forecaster's own chance of this, stated with the estimate: 30%; middle value at least 1.1-fold (0.07 log units) away from the limit.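

In this assay, 2,5-difluorophenyl, which carries two fluorine atoms, now joins the three rings already shown on the aromatic nitrogen, and both readable steps remain small as far as they go: an at least 1.1-fold higher number from compound 3 to compound 4 (0.07 log units; that floor lies within the scatter) and an at least 1.2-fold higher number from compound 1 to compound 4 (0.09 log units; that floor lies within the scatter). The step between compound 2 and compound 4 cannot be read, as both values are limits. This position has now taken a fourth substituted phenyl ring with no step shown beyond the scatter, and reaching the limit is no longer confined to compound 2 and its 4-aminophenyl group: the limit of > 20000 nM in this assay, at which 2 of the 4 values shown sit.

Going by these compounds, compound 2 and compound 4 give only floors, so how far they lie from compound 1 and compound 3 remains unknown, and a real gap cannot be ruled out. All four groups shown are substituted phenyl rings, so it remains open whether the read-out would stay within the scatter with a carboxylic acid on that ring, or with a plain alkyl chain in place of the ring.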